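The compounds below may be only part of what the source reports. "The series", "measured", "known", "first", "only" and "open" are said of these compounds alone.

Measured compounds:
Compound 1, `CCOCc1cc(O)c(O)c(Br)c1` — in a functional assay on HCT-116 cells (Homo sapiens) for cytotoxicity, read by MTT assay, with a stated time of 96 h (on this read-out lower numbers stand for stronger inhibition and higher numbers for weaker inhibition), compound 1 gives "not determined" (no result reported).
Compound 2, `CCOCc1cc(O)c(O)c(Br)c1Br` — in this assay compound 2 gives 2510 nM.
Compound 3, `OCc1cc(O)c(O)c(Br)c1Br` — not yet measured.

Compound 2 stands alone on the numbers: its value is the only one in hand, and compound 1 offers no figure against which it could be set. Among the compounds with values here, no pair of measured compounds differs in a single place, so no step in this assay has been quantified, and nothing can be said about how the ethoxymethyl group or the two bromines on the core of compound 2 contribute.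

Compound 3 keeps the core of compound 2 and differs from it by hydrogen in place of ethyl on an oxygen on a saturated carbon.

Within the data shown here, with no measured step to lean on, the expectation rests on the small scale of the change. In this assay the step from compound 2 to compound 3 is expected to be modest, if present at all, and no larger than the usual scatter, with weaker inhibition slightly more likely than stronger. The estimated step is a 1.3-fold higher number from compound 2 to compound 3 (0.11 log units; within the scatter). Compound 3 is therefore estimated at 3200 nM, within a range from 1200 nM to 8500 nM.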

Compound 3, half-maximal inhibitory concentration: 20400 nM
Estimate against measurement, compound 3: 6.4-fold (0.80 log units) below; the whole stated range lies below it.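

In this assay, within the data shown here, the result puts a number on this position for the first time: the step is an 8.1-fold higher number from compound 2 to compound 3 (0.91 log units; beyond the scatter) and it lies beyond the scatter, so exchanging the ethyl on this oxygen for hydrogen, which turns ethoxymethyl into hydroxymethyl, clearly weakens inhibition. Compound 2 alone could say nothing about this side chain, whereas the pair shows that the read-out responds to what sits on that oxygen, with compound 2 the stronger of the two. The data offer no measurement that accounts for the size of this step.

The compounds shown leave open whether the number follows the length of the chain on this oxygen, as neither a methyl ether nor a longer chain such as propyl or butyl is among them, and neither is an amine or a carboxylic acid in place of the hydroxymethyl group. From the compounds shown here alone, compound 1 gives "not determined" (no result reported) and its step to compound 2 cannot be read, so the contribution of the extra bromine of compound 2 also stays open.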